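Swapping isobutyl for sec-butyl on an inactive compound

The source may hold more compounds than are shown below. What is called first, only, known or untested is meant among the compounds shown, and "the series" means these compounds.

Compound 1 `CC(C)CNC(=C\C(=O)/C=C/c1ccc(O)cc1)/C=C/c1ccc(O)cc1` was tested in an ADME assay on EA.hy 926 cells (Homo sapiens) for inhibition, read by sulforhodamine B assay, with a stated time of 72 h; a lower number here means a stronger inhibitor, a higher number a weaker inhibitor. In that assay, compound 1 gives > 25000 nM, which is a limit and not a number. Compound 2 `COc1cc(/C=C/C(=O)/C=C(/C=C/c2ccc(OC(C)=O)c(OC)c2)NCC(C)C)ccc1OC(C)=O` gives > 25000 nM in this assay, which is also a limit. Compound 1 therefore stands with its neighbour at the limit of > 25000 nM in this assay, at which 2 of the 2 values shown sit, so no measured potency is yet available for either compound.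

Compound 3 `CCC(C)NC(=C\C(=O)/C=C/c1ccc(O)cc1)/C=C/c1ccc(O)cc1` has sec-butyl in place of isobutyl on an amine nitrogen, and the two have the same atoms, joined differently: sec-butyl in place of isobutyl on an amine nitrogen. For the measured compounds named here, no measured pair shows what a change at this place does, so the forecast has little to rest on. The expectation rests on compound 1, which gives > 25000 nM in this assay, and on how small the structural change is. No clear change in either direction is expected, and the expected step of a number no higher from compound 1 to compound 3 (the limit leaves the size open) stays within the usual scatter. Compound 3 may well also reach the limit of the assay. For compound 3 the estimated value is 25000 nM, with an expected range from 10000 nM to 50000 nM.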

Compound 3, half-maximal inhibitory concentration: > 25000 nM
Compound 3: a limit, no number; the forecaster's own chance of this, stated with the estimate: 75%; the middle value sits exactly at the limit.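

In this assay compound 3 gives > 25000 nM, which is a limit and not a number. Compound 1 also stands at a limit, so no step can be read between compound 1 and compound 3. The compounds shown leave open how strongly any of them inhibits and whether sec-butyl and isobutyl differ at all, as every result sits at one limit: the limit of > 25000 nM in this assay, at which 3 of the 3 values shown sit.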